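The source may report more compounds than this note shows. Statements on the series, on what has been measured and on what is new or still open speak of the compounds shown alone.

Values measured so far in a physicochemical assay for lipophilicity, at pH 7.4; on this read-out higher numbers stand for higher lipophilicity and lower numbers for lower lipophilicity:

- Compound 1 `CCCn1nc2c(=O)[nH]c(-c3cc(S(=O)(=O)N4CCN(CC)CC4)cnc3OCCOC)nc2c1CC`: 1
- Compound 2 `CCc1c2nc(-c3cc(S(=O)(=O)N4CCN(CC)CC4)cnc3OCCOC)[nH]c(=O)c2nn1C(C)C`: 1
- Compound 3 `CCc1c2nc(-c3cc(S(=O)(=O)N4CCN(CC)CC4)cnc3OCCOC)[nH]c(=O)c2nn1CCOC`: 1.4

Compound 3 stands highest of the three in this assay. Compound 4 `CCc1c2nc(-c3cc(S(=O)(=O)N4CCN(CC)CC4)cnc3OCCOC)[nH]c(=O)c2nn1CC1CC1` differs from it in one place: cyclopropyl in place of methoxymethyl on a saturated chain carbon bound to an aromatic nitrogen. Put another way, 2-methoxyethyl gives way to cyclopropylmethyl. Within the data shown here, two measured steps bear most directly on this, both modest and both towards the oxygen-bearing chain: a number 0.40 log units higher from compound 1 to compound 3 (beyond the scatter) and a number 0.40 log units higher from compound 2 to compound 3 (beyond the scatter). Changing only the shape of the carbon chain gave no change at the digits printed from compound 1 to compound 2 (within the scatter). Among the measured compounds shown here, compound 4 loses that oxygen, but no measured compound carries a ring here, so a modest drop is only tentatively expected: a number 0.30 log units lower from compound 3 to compound 4 (within the scatter). Compound 4 is estimated at 1.1, with an expected range of 0.7 to 1.5.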

Compound 4, distribution coefficient: 1
For compound 4 the middle estimate is 0.10 log units above the measured one, within the range that was stated.
By their numbers in this assay, from the lowest: compounds 1, 2 and 4 (each within the scatter of the next); then compound 3.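

Exchanging 2-methoxyethyl for cyclopropylmethyl gives a number 0.40 log units lower from compound 3 to compound 4 (beyond the scatter) in this assay, so the higher reading of compound 3 also holds against a chain carrying a ring. The ring itself stands level with the open carbon chains, with no change at the digits printed from compound 2 to compound 4 (within the scatter) and no change at the digits printed from compound 1 to compound 4 (within the scatter), which leaves compound 3, the only one here with oxygen in this chain, apart from the other three. Nothing measured here explains this difference.

Still open, on these data alone, is how an amine or a hydroxyl-ended chain on this aromatic nitrogen would read in this assay. As far as these compounds go, a longer chain with oxygen in it is equally open.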